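A Formyl Group Replaces Bromo Where Only Limits Stand

This account rests on a few compounds, and the source may have more. Where it says the series, first, only, none or still open, it means among the compounds named here.

In an ADME assay on H9 cells (Homo sapiens) for cytotoxicity, read by XTT assay, with a stated time of 6 days (on this read-out lower numbers stand for higher toxicity in this test and higher numbers for lower toxicity in this test), compound 1 (`Cc1cc(C#N)cc(C)c1Oc1cc(Nc2ccc(C#N)cc2)c([N+](=O)[O-])cc1[N+](=O)[O-]`) gives > 58200 nM as a limit. Compound 2 (`Cc1cccc(C)c1Oc1cc(Nc2ccc(C#N)cc2)c([N+](=O)[O-])cc1[N+](=O)[O-]`) gives > 61800 nM as a limit. Compound 3 (`Cc1cc(Br)cc(C)c1Oc1cc(Nc2ccc(C#N)cc2)c([N+](=O)[O-])cc1[N+](=O)[O-]`) gives > 51700 nM as a limit, so it stands without a number, as do the other two. Compound 4 (`Cc1cc(C=O)cc(C)c1Oc1cc(Nc2ccc(C#N)cc2)c([N+](=O)[O-])cc1[N+](=O)[O-]`) carries formyl in place of bromo on an aromatic carbon. For the measured compounds named here, the steps that bear on this change are a step that the two limits leave unreadable from compound 1 to compound 3 and a step that the two limits leave unreadable from compound 2 to compound 3 and a step that the two limits leave unreadable from compound 1 to compound 2 and none has a readable size. Only a small move toward higher toxicity in this test, if any, is therefore expected in this assay. The expected change is an at least 1.0-fold lower number from compound 3 to compound 4 (0.01 log units; that floor lies within the scatter) in size. For compound 4 the estimate is 50000 nM with an expected range from 15000 nM to 60000 nM in this test.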

Compound 4, half-maximal cytotoxic concentration: 57900 nM
Beside the measured number, compound 4's estimate is 1.2-fold (0.06 log units) below it, within the range that was stated.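

In this assay, for the compounds shown here, compound 4 gives 57900 nM, the first measured number at this position, para to a large group. The other compounds shown stand only as limits. Formyl in place of hydrogen gives an at least 1.0-fold lower number from compound 2 to compound 4 (0.02 log units; that floor lies within the scatter), so this change shows no step beyond the scatter. Formyl in place of cyano gives a number no higher from compound 1 to compound 4 (the limit leaves the size open). The step to formyl from bromo cannot be read in size.

On these data alone, the true numbers behind the three limits remain open. So does the result for an amine or a carboxylic acid at this position on the shared core.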